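The source may hold more compounds than are shown below. What is called first, only, known or untested is meant among the compounds shown, and "the series" means these compounds.

In an ADME assay on THP-1 cells (Homo sapiens) for cytotoxicity, read by fluorescence and resazurin assay, with a stated time of 72 h (on this read-out higher numbers stand for lower toxicity in this test and lower numbers for higher toxicity in this test), compound 1 `Cc1cccc2c(CN3CCC(NS(C)(=O)=O)C3)c(-c3ccccc3)[nH]c12` gives 32000 nM. Compound 2 `O=S(=O)(NC1CCN(Cc2ccncc2)CC1)c1ccc(-n2cccn2)cc1` gives > 64000 nM, which is a limit of the assay and not a number. Its place on the scale is therefore known only as the limit of > 64000 nM in this assay, at which 1 of the 2 values shown sits. Compound 3 `Cc1cc(-n2cccn2)ccc1S(=O)(=O)NC1CCN(Cc2ccncc2)CC1` differs from compound 2 in one place, with methyl in place of hydrogen on an aromatic carbon. Among the compounds with values here, no measured pair in this small set shows the same kind of change, so the expectation rests on the size of the change and on where compound 2 stands. No step beyond the usual scatter is expected in this assay, in either direction. The estimated change is a number no higher from compound 2 to compound 3 (the limit leaves the size open). For compound 3 the expected half-maximal cytotoxic concentration is 64000 nM, with an estimated range from 32000 nM to 128000 nM. A reading reported only as a limit would also be expected.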

Compound 3, half-maximal cytotoxic concentration in the THP-1 assay: 32000 nM
Compound 3: the middle estimate sits 2.0-fold (0.30 log units) above what was measured; measured number inside the range.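

With methyl in place of hydrogen on an aromatic carbon, ortho to a large group and meta to a 1H-pyrazol-1-yl group, the THP-1 assay gives an at least 2.0-fold lower number from compound 2 to compound 3 (0.30 log units; that floor lies within the scatter). Compound 2 is held there only by a limit of the assay, so this pair fixes a floor for the step and not its size: the limit of > 64000 nM in the THP-1 assay, at which 1 of the 3 values shown sits. In a physicochemical assay for solubility (on this read-out lower numbers stand for lower solubility and higher numbers for higher solubility), compound 2 gives 149000 nM and compound 3 gives 66000 nM. In the physicochemical assay, the same methyl goes with lower solubility, the first change at this position shown to lie beyond the scatter: the measured solubility of compound 2, 149000 nM, and of compound 3, 66000 nM, a 2.3-fold lower number (0.35 log units; beyond the scatter)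

The compounds shown leave open how far the cytotoxic concentration of compound 2 lies beyond its limit, and so how large the true step is. They also leave open whether a methoxy group or an amine on the same aromatic carbon would move either read-out in the same way.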